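This account rests on a few compounds, and the source may have more. Where it says the series, first, only, none or still open, it means among the compounds named here.

Of the compounds shown here, three that share a core have been measured in an assay on isolated protein for inhibition of Apoptosis regulator Bcl-2 (Homo sapiens), read by fluorescence polarization, with stated times of 5 min and 10 min; a higher number here means a weaker inhibitor, a lower number a stronger inhibitor. Compound 1, `CC1(C)CCCC2=C1C[C@@H](C(=O)O)[C@H](c1ccccc1)C2`, carries a free carboxylic acid; in this assay compound 1 reaches only the limit > 23000 nM, which is not a number. Compound 2, `COC(=O)c1ccc(NC(=O)[C@H]2CC=C(CCC=C(C)C)C[C@@H]2c2ccccc2)cc1`, carries an amide to an aromatic ring bearing a methyl ester; compound 2 also stops at the limit > 23000 nM. Within the data shown here, compound 3, `CONC(=O)[C@@H]1CC=C(CCC=C(C)C)C[C@H]1c1ccccc1`, is the methoxyamide; in this assay compound 3 gives 2700 nM, the only actual number among the three. Compound 1 and compound 2 both sit at a limit, as recorded in the limit of > 23000 nM in this assay, at which 2 of the 3 values shown sit.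

Compound 4, `CC(C)=CCCC1=CC[C@@H](C(=O)Nc2ccc(O)cc2)[C@H](c2ccccc2)C1`, is not yet measured. It differs from compound 3 in one place: 4-hydroxyphenyl in place of methoxy on an amide-type nitrogen. Among the measured compounds shown here, compound 2 is the only other compound with an aromatic ring on the amide nitrogen, and compound 2 shows only the limit > 23000 nM. On that basis the step from compound 3 to compound 4 is expected to run toward weaker inhibition, by a 3.3-fold higher number from compound 3 to compound 4 (0.52 log units; beyond the scatter), beyond the usual scatter. For compound 4 the expected value in this assay is 9000 nM, with a likely range from 2500 nM to 30000 nM, and a real chance that only a limit is reported.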

Compound 4, inhibition constant: > 23000 nM
Compound 4 gave a limit, no number; the forecaster's own chance of this, stated with the estimate: 35%; at least 2.5-fold (0.40 log units) between middle value and limit.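

With only one place changed on the amide-type nitrogen, this assay gives a directly readable change: an at least 8.5-fold higher number from compound 3 to compound 4 (0.93 log units; beyond the scatter), and this rests on a limit for compound 4, so the true gap could be larger. Compound 4 carries a hydroxy on its aromatic ring rather than the methyl ester of compound 2, yet it also yields no number, so the loss does not depend on that ester alone. Among the compounds shown, methoxy is the only group on this nitrogen that gives an actual number, and the limit is where most of the set now sits: the limit of > 23000 nM in this assay, at which 3 of the 4 values shown sit.

From the compounds shown here alone, since compound 2 and compound 4 both stop at a limit, their aromatic groups cannot be ranked against each other, and it remains unknown how far beyond the limit either one lies. Also open, going by these compounds, is whether the number survives with ethoxy or hydroxy on this nitrogen, or with a benzyl group, which would separate the effect of replacing the oxygen-linked group from that of placing an aromatic ring directly on the nitrogen.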